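Swapping the aryl on the ring nitrogen: an expected outcome

The source may hold more compounds than are shown below. What is called first, only, known or untested is meant among the compounds shown, and "the series" means these compounds.

Compound 3 `COc1ccc(-n2nc(-c3ccc(C(F)(F)F)cc3O)nc2-c2ccccc2O)cc1` gives 69% in a functional assay on PC-12 cells (Rattus norvegicus) for cytotoxicity, read by MTT assay, with stated times of 2 h and 24 h, tested at 1 uM; on this read-out higher numbers stand for a stronger effect at the one concentration tested and lower numbers for a weaker effect; its number is the lowest of the three shown, though within the scatter of each neighbour, since compound 1 `Oc1cc(C(F)(F)F)ccc1-c1nc(-c2ccccc2O)n(-c2ccc(Br)cc2)n1` gives 69.4% and compound 2 `Oc1cc(C(F)(F)F)ccc1-c1nc(-c2ccccc2O)n(-c2ccc(C(F)(F)F)cc2)n1` gives 70.7%. The measured steps, a number 1.3 percentage points higher from compound 1 to compound 2 (within the scatter), a number 0.4 percentage points lower from compound 1 to compound 3 (within the scatter) and a number 1.7 percentage points lower from compound 2 to compound 3 (within the scatter), each exchange one substituent for another on an aromatic carbon and each stays within the scatter. Compound 4 `Cc1ccc(-n2nc(-c3ccc(C(F)(F)F)cc3O)nc2-c2ccccc2O)c(C)c1` differs from compound 3 by 2,4-dimethylphenyl in place of 4-methoxyphenyl on an aromatic nitrogen. This is a larger exchange than any measured, yet every prior change on that aryl group left the read-out unmoved, so a step of about no change at the digits printed from compound 3 to compound 4 (within the scatter) is expected, none beyond the scatter. Compound 4 is estimated at 69%, between 59% and 79%.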

Compound 4, a percentage reported as activity, at one concentration (the size of the read-out at that concentration, not a potency): 73.7%
Estimate against measurement, compound 4: 4.7 percentage points below; measured number inside the range.
By their numbers in this assay, from the lowest: compounds 3, 1, 2 and 4 (each within the scatter of the next).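

In this assay, the aromatic nitrogen also accepts 2,4-dimethylphenyl, an aryl group of carbon only, with a number 4.7 percentage points higher from compound 3 to compound 4 (within the scatter) and a number 3 percentage points higher from compound 2 to compound 4 (within the scatter) and a number 4.3 percentage points higher from compound 1 to compound 4 (within the scatter) as the steps, all within the scatter. Among these compounds, four different aryl groups at this position therefore give read-outs that no step separates. No measurement shown offers an explanation for these numbers. The compounds shown leave open whether an amine or a carboxylic acid on this aryl group, or a longer alkyl chain in its place, would give a step beyond the scatter.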